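This account rests on a few compounds, and the source may have more. Where it says the series, first, only, none or still open, it means among the compounds named here.

Measured in an assay on cells for inhibition of Indoleamine 2,3-dioxygenase 1 (Homo sapiens), with a stated time of 7 h, tested at 200 uM; on this read-out higher numbers stand for more inhibition at the one concentration tested (going by the name of the read-out) and lower numbers for less inhibition:
compound 1, `c1ccc(Cc2ccccc2-c2c[nH]nn2)cc1`: 84%
compound 2, `c1ccc(CCc2ccccc2-c2c[nH]nn2)cc1`: 58%

Compound 2 stands lowest of the two numbers; its nearest neighbour, compound 1, lies higher by a margin beyond the scatter. Compound 3, `c1ccc(-c2c[nH]nn2)c(CCC2CCCC2)c1`, is not yet measured. It differs from compound 2 by cyclopentyl in place of phenyl on a saturated chain carbon, two bonds along the chain from an aromatic carbon. For the measured compounds named here, no measured pair follows this change, so its size is unknown; a modest decrease in this assay is expected, though none beyond the scatter is possible. Compound 3 is estimated at 45%, within 20% to 70%, an expected step of a number 13 percentage points lower from compound 2 to compound 3 (beyond the scatter).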

Compound 3, a percentage reported as inhibition, at one concentration (the size of the read-out at that concentration, not a potency): 74%
Beside the measured number, compound 3's estimate is 29 percentage points below it; the whole stated range lies below it.
By their numbers in this assay, from the lowest: compound 2; then compounds 3 and 1 (each within the scatter of the next).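

In this assay, cyclopentyl in place of phenyl on a saturated chain carbon, two bonds along the chain from an aromatic carbon, gives a number 16 percentage points higher from compound 2 to compound 3 (beyond the scatter), so an aromatic ring is not required at this place in this series. Cyclopentylmethyl in place of phenyl on a saturated chain carbon bound to an aromatic carbon gives a number 10 percentage points lower from compound 1 to compound 3 (within the scatter), so this read-out does not separate these two compounds. Nothing available bears on the reason for either step.

Open, going by these compounds, is whether cyclohexyl, a longer chain or an amine at this place would hold the inhibition. These single-concentration numbers also leave potency open.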